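The source may hold more compounds than are shown below. What is called first, only, known or untested is meant among the compounds shown, and "the series" means these compounds.

In a functional assay on MES-SA cells (Homo sapiens) for cytotoxicity, read by luminescence and CellTiter-Glo, with a stated time of 72 h (on this read-out lower numbers stand for stronger inhibition and higher numbers for weaker inhibition), compound 1 (`COC[C@H](NC(=O)c1cc(OC)no1)C(=O)N[C@@H](COC)C(=O)N[C@@H](CC(C)C)C(=O)[C@@]1(C)CO1`) gives 12 nM, and compound 2 (`COC[C@H](NC(=O)c1cc(C)on1)C(=O)N[C@@H](CC(C)C)C(=O)N[C@@H](CC(C)C)C(=O)[C@@]1(C)CO1`) gives 45 nM. Compound 2 therefore holds the higher of the two numbers and is the weaker inhibitor of the pair, with a gap beyond the usual scatter. Compound 3 (`COC[C@H](NC(=O)c1cc(C)on1)C(=O)N[C@@H](C)C(=O)N[C@@H](CC(C)C)C(=O)[C@@]1(C)CO1`) has not yet been measured. It differs from compound 2 by a single change: hydrogen in place of isopropyl on a saturated chain carbon, two bonds along the chain from an amide-type nitrogen and a carbonyl carbon. This places hydrogen in place of isopropyl on a saturated chain carbon, two bonds along the chain from an amide-type nitrogen and a carbonyl carbon, and the same difference, cut one bond further out, reads isobutyl to methyl. For the measured compounds named here, no measured pair here shows this change on its own, so the data give neither its size nor its direction. The expectation therefore stays anchored on compound 2 at 45 nM, with no shift beyond the scatter expected in this assay and only a slight lean towards a higher number. The estimated step is a 1.3-fold higher number from compound 2 to compound 3 (0.12 log units; within the scatter). The value expected for compound 3 is 60 nM, within an estimated range of 20 nM to 180 nM.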

Compound 3, half-maximal inhibitory concentration in the MES-SA assay: 28 nM
Estimate against measurement, compound 3: 2.1-fold (0.33 log units) above; measured number inside the range.
By their numbers in the MES-SA assay, from the lowest: compound 1; then compounds 3 and 2 (each within the scatter of the next).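

For the compounds shown here, at this saturated chain carbon, two bonds along the chain from an amide-type nitrogen and a carbonyl carbon, compounds 2 and 3 form the first pair that isolates a single change, and isobutyl to methyl gives in the MES-SA assay a 1.6-fold lower number from compound 2 to compound 3 (0.21 log units; within the scatter), so the larger side chain is not needed to keep the cytotoxicity seen in this pair. In a physicochemical assay for metabolic stability, in simulated intestinal fluid, with a stated time of 15 min, tested at 4 uM (on this read-out lower numbers stand for a less stable compound and higher numbers for a more stable compound), the same change gives a number 10 percentage points higher from compound 2 to compound 3 (within the scatter), with compound 2 at 90% and compound 3 at 100%, so neither read-out separates the two compounds. Nothing in the data shown accounts for this tolerance.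

Going by these compounds alone, whether the position also tolerates a carboxylic acid, an amine or a phenyl ring remains open, since isobutyl and methyl are the only groups compared here with the rest of the structure held constant. Compound 1 differs from compound 3 in more than one place, so in the MES-SA assay the value of compound 1, 12 nM, cannot be tied to any single change.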